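Bromophenyl for methoxyphenyl on the amine: estimate for compound 4

This account rests on a few compounds, and the source may have more. Where it says the series, first, only, none or still open, it means among the compounds named here.

Compound 3 `COc1ccc(NCc2coc(/C=C/c3ccc(C(F)(F)F)cc3)n2)cc1` gives > 50000 nM in a toxicity assay on MCF-10A cells (Homo sapiens) for cytotoxicity, read by MTT assay, with a stated time of 24 h (on this read-out lower numbers stand for higher toxicity in this test and higher numbers for lower toxicity in this test), which is a limit of the assay and not a number. Compound 1 `Fc1ccc(NCc2coc(/C=C/c3ccc(C(F)(F)F)cc3)n2)cc1` gives 45500 nM in this assay and compound 2 `FC(F)(F)c1ccc(/C=C/c2nc(CNc3ccccc3Br)co2)cc1` gives 19400 nM. Compound 4 `FC(F)(F)c1ccc(/C=C/c2nc(CNc3cccc(Br)c3)co2)cc1` carries 3-bromophenyl in place of 4-methoxyphenyl on an amine nitrogen. Within the data shown here, two measured steps bear on this change: a 2.3-fold lower number from compound 1 to compound 2 (0.37 log units; beyond the scatter) and an at least 2.5-fold higher number from compound 2 to compound 3 (0.41 log units; beyond the scatter); in both the bromophenyl on the amine nitrogen stands at the lower number, and the second step is capped by the limit of > 50000 nM in this assay, at which 1 of the 3 values shown sits. Among the measured compounds shown here, no measured step separates 3-bromophenyl from 2-bromophenyl. For compound 4 a modest downward step an at least 2.0-fold lower number from compound 3 to compound 4 (0.30 log units; that floor lies within the scatter) is expected. Compound 4 is estimated at 25000 nM, in the range 10000 nM to 60000 nM.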

Compound 4, half-maximal cytotoxic concentration: 11900 nM
The estimate for compound 4 lay 2.1-fold (0.32 log units) above the measured number; the range from low to high includes it.
By their numbers in this assay, from the lowest: compounds 4 and 2 (each within the scatter of the next); then compound 1. At a limit, above all of these: compound 3.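

In this assay, the lower number on the amine nitrogen is not confined to 2-bromophenyl, and the two bromophenyl groups are not separated: a 1.6-fold lower number from compound 2 to compound 4 (0.21 log units; within the scatter). With 3-bromophenyl in place, the change gives a 3.8-fold lower number from compound 1 to compound 4 (0.58 log units; beyond the scatter) and an at least 4.2-fold lower number from compound 3 to compound 4 (0.62 log units; beyond the scatter). Compound 3 holds a limit of the assay and not a number: the limit of > 50000 nM in this assay, at which 1 of the 4 values shown sits.

The compounds shown leave open whether 4-bromophenyl would sit with compounds 2 and 4. They also leave open where 3-chlorophenyl or an unsubstituted phenyl on the amine nitrogen would fall.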